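Removing the hydroxy from compound 2: expected outcome

This account rests on a few compounds, and the source may have more. Where it says the series, first, only, none or still open, it means among the compounds named here.

compound 1 `COc1ccc(-n2nc(C(=O)Nc3ccc(C)cc3)nc2-c2cc(OC)c(OC)c(OC)c2)cc1` — 60%
compound 2 `COc1ccc(-n2nc(C(=O)Nc3ccc(O)cc3)nc2-c2cc(OC)c(OC)c(OC)c2)cc1` — 35%

For the measured compounds named here, in a functional assay on the whole organism for inhibition, with Rattus norvegicus as the target, read by paw edema, with stated times of 30 min and 2 h, at a dose of 0.28 mmol/kg by the oral route (on this read-out lower numbers stand for less inhibition and higher numbers for more inhibition at the one dose given (going by the name of the read-out)), compound 1 gives 60% and compound 2 gives 35%; compound 2 stands lowest of the two, the single measured step being a number 25 percentage points lower from compound 1 to compound 2 (beyond the scatter). Compound 3 `COc1ccc(-n2nc(C(=O)Nc3ccccc3)nc2-c2cc(OC)c(OC)c(OC)c2)cc1` differs from compound 2 by hydrogen in place of hydroxy on an aromatic carbon. Going by the values given here, no measured step covers this exact change; only the step from methyl to hydroxy bears on it indirectly, and it was modest. Because of a number 25 percentage points lower from compound 1 to compound 2 (beyond the scatter) the value for compound 3 is estimated at 50%, with a range from 35% to 65%. The expected step is a number 15 percentage points higher from compound 2 to compound 3 (beyond the scatter).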

Compound 3, a percentage reported as inhibition, in the whole organism at one dose (the size of the read-out at that dose, not a potency): 51%
Estimate against measurement, compound 3: 1 percentage points below; the range from low to high includes it.
By their numbers in this assay, from the lowest: compound 2; then compounds 3 and 1 (each within the scatter of the next).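

Replacing the hydroxy with hydrogen on this aromatic carbon, para to a large group, gives a clear change (a number 16 percentage points higher from compound 2 to compound 3 (beyond the scatter)), so the low reading of compound 2 goes with the hydroxy itself. Hydrogen in place of methyl at the same carbon gives no change that can be told from scatter (a number 9 percentage points lower from compound 1 to compound 3 (within the scatter)), so the methyl is not shown to be needed. Nothing measured bears on the reason for the hydroxy difference. Still open, as far as these compounds go, is whether an amine or a carboxylic acid on this carbon would read like the hydroxy or like hydrogen and methyl.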